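A few compounds are considered here, and "the series" means these few. Any claim that something is new, unique, unknown or untested is made for them only; others in the source may bear on it.

Three compounds share one core. In an assay on FRT-Jurkat cells for inhibition of nuclear factor NF-kappa-B complex (Homo sapiens), read by flow cytometry, with a stated time of 24 h, tested at 10 uM (a lower number here means less inhibition, a higher number more inhibition at the concentration tested (going by the name of the read-out)), compound 1 `O=C1CCC(N2C(=O)c3cccc(Nc4ccccn4)c3C2=O)C(=O)N1` gives 1%, compound 3 `Cc1ccccc1Nc1cccc2c1C(=O)N(C1CCC(=O)NC1=O)C2=O` gives 7%, and compound 2 `O=C1CCC(N2C(=O)c3ccc(Nc4ccc(O)cc4)cc3C2=O)C(=O)N1` gives 4%. Compound 2 stands second of the three numbers, yet all three lie within the scatter of one another. For the measured compounds named here, the only measured step that swaps the group on that nitrogen is a number 6 percentage points higher from compound 1 to compound 3 (within the scatter), which stays within the scatter. Compound 4 `Cc1ccccc1Nc1ccc2c(c1)C(=O)N(C1CCC(=O)NC1=O)C2=O` differs from compound 2 by 2-methylphenyl in place of 4-hydroxyphenyl on a nitrogen on an aromatic ring. Compound 3 already carries the entering 2-methylphenyl group and gives 7%, so no movement beyond the scatter is expected. The expected step is a number 1 percentage points higher from compound 2 to compound 4 (within the scatter). The estimate for compound 4 in this assay is 5%, between -5% and 15%.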

Compound 4, a percentage reported as inhibition, at one concentration (the size of the read-out at that concentration, not a potency): 2%
For compound 4 the middle estimate is 3 percentage points above the measured one, within the range that was stated.
By their numbers in this assay, from the lowest: compounds 1, 4, 2 and 3 (each within the scatter of the next).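

Putting 2-methylphenyl in place of 4-hydroxyphenyl on this nitrogen gives a number 2 percentage points lower from compound 2 to compound 4 (within the scatter) in this assay. This second swap on the nitrogen involves a different leaving group from the first, yet like a number 6 percentage points higher from compound 1 to compound 3 (within the scatter) it stays within the scatter, so neither step shows the group on this nitrogen affecting the read-out. Nothing available explains this result. The compounds shown leave open whether any group here can move the read-out beyond the scatter. A carboxylic acid or a longer chain on this nitrogen would test that.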